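Two Limits and a Fluorine: What Compound 3 May Show

The source may report more compounds than this note shows. Statements on the series, on what has been measured and on what is new or still open speak of the compounds shown alone.

Compound 1, `CS(=O)(=O)c1ccc(-c2oc3ccccc3c(=O)c2-c2cccc(Cl)c2)cc1`, in an assay on isolated protein for inhibition of prostaglandin G/H synthase 1 (Mus musculus), tested at 10 ug/mL (a higher number here means more inhibition at the concentration tested (going by the name of the read-out), a lower number less inhibition), gives < 5%.
Compound 2, `CS(=O)(=O)c1ccc(-c2oc3ccccc3c(=O)c2-c2cc(Cl)cc(Cl)c2)cc1`, in this assay gives < 5%.

Each of these values is a limit of the assay, not a number. Compound 2 therefore stands at the assay floor, and the step that the two limits leave unreadable from compound 1 to compound 2 cannot be sized because of the limit of < 5% in this assay, at which 2 of the 2 values shown sit. Compound 3, `CS(=O)(=O)c1ccc(-c2oc3ccccc3c(=O)c2-c2cccc(F)c2)cc1`, differs from compound 2 by 3-fluorophenyl in place of 3,5-dichlorophenyl on an aromatic carbon. Going by the values given here, the one measured step bears on this change only in that the chloro substitution left the read-out at the limit; no size can be drawn from it. Compound 3 is accordingly expected to give 3%, within 0% to 10%. The expected step that the limit leaves unreadable from compound 2 to compound 3 is estimated to lie within the scatter, with no reading beyond the limit anticipated.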

Compound 3, a percentage reported as inhibition, at one concentration (the size of the read-out at that concentration, not a potency): < 5%
Compound 3 was reported as a limit; the forecaster's own chance of this, stated with the estimate: 80%; the middle value is on the limit's open side.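

Going by these compounds alone, no step among compound 1, compound 2 and compound 3 can be read in this assay, because each value is a limit and not a number: the limit of < 5% in this assay, at which 3 of the 3 values shown sit. On these data alone, whether the chloro or fluoro changes alter inhibition at all remains open.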